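Extending the nitrogen substituent in a fused tricyclic amine series

This account rests on a few compounds, and the source may have more. Where it says the series, first, only, none or still open, it means among the compounds named here.

Compounds measured so far:
compound 1 `Cc1nc2cc3c(cc2n1C)C1CNCC3C1` gives 0.31 nM in an assay on HEK293 cells for binding affinity to Neuronal acetylcholine receptor; alpha4/beta2 (Homo sapiens); on this read-out lower numbers stand for stronger inhibition and higher numbers for weaker inhibition
compound 2 `Cn1cnc2cc3c(cc21)C1CNCC3C1` gives 0.75 nM in this assay
compound 3 `CC(=O)c1ccc2c(c1)C1CNCC2C1` gives 0.17 nM in this assay

Compound 2 stands at the highest number of the three, with compound 1 nearest and compound 3 furthest. Compound 4 `CCCCn1cnc2cc3c(cc21)C1CNCC3C1` differs from compound 2 by propyl in place of hydrogen on a saturated chain carbon bound to an aromatic nitrogen. Within the data shown here, the only measured step, a 2.4-fold higher number from compound 1 to compound 2 (0.38 log units; beyond the scatter), concerns a methyl on an aromatic carbon, a different place, so it offers no direct precedent for growing the chain on the nitrogen. With nothing closer to lean on, only a modest shift in this assay is expected, in either direction or none beyond the scatter. Compound 4 is therefore estimated at 1 nM, within 0.3 nM to 4 nM, a step of a 1.3-fold higher number from compound 2 to compound 4 (0.12 log units; within the scatter).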

Compound 4, inhibition constant: 0.2 nM
Beside the measured number, compound 4's estimate is 5.0-fold (0.70 log units) above it; the whole stated range lies above it.
By their numbers in this assay, from the lowest: compounds 3, 4 and 1 (each within the scatter of the next); then compound 2.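

Growing methyl to butyl on the aromatic nitrogen gives a 3.8-fold lower number from compound 2 to compound 4 (0.57 log units; beyond the scatter) in this assay. This shows that the position accepts a longer saturated chain, and that here the added propyl lowers the number rather than raising it. Nothing measured here gives a reason for this shift.

A single step cannot show whether the number would keep falling with a longer chain such as hexyl. The compounds shown also leave open what a chain ending in an amine or a carboxylic acid would do at this nitrogen.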